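A few compounds are considered here, and "the series" means these few. Any claim that something is new, unique, unknown or untested is made for them only; others in the source may bear on it.

Measured in an ADME assay on J774 cells (Mus musculus) for antiproliferative activity, with a stated time of 72 h; a higher number here means that more compound is needed for the effect, a lower number that less compound is needed:

- Compound 1 `CCCCc1cc2c(=O)c(CC)c(C)[nH]c2cc1OCCOc1ccccc1`: 1000 nM
- Compound 2 `CCc1c(C)[nH]c2cc(OCCOc3ccccc3)c(OC)cc2c1=O`: > 29000 nM (a limit of the assay)

Going by the values given here, compound 1 holds the only actual number, since the other result is a limit. Compound 3 `CCCCc1cc2c(=O)c(-c3ccc(C(F)(F)F)cc3C)c(C)[nH]c2cc1OCCOc1ccccc1` has 2-methyl-4-(trifluoromethyl)phenyl in place of ethyl on an aromatic carbon of the core of compound 1 (2-methyl-4-(trifluoromethyl)phenyl in place of ethyl on an aromatic carbon). Among the compounds with values here, the one measured step is large: an at least 29-fold higher number from compound 1 to compound 2 (1.46 log units; beyond the scatter). That step ends at a limit, (the limit of > 29000 nM in this assay, at which 1 of the 2 values shown sits), and it lies at another place on the core, so it shows that this assay can respond to a change but does not size this one. Within the data shown here, no measured step covers the ethyl group. A moderate move towards a higher number is therefore expected, with wide uncertainty. The step expected is a 2.5-fold higher number from compound 1 to compound 3 (0.40 log units; beyond the scatter). For compound 3 the estimated value is 2500 nM, with an expected range of 400 nM to 15000 nM.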

Compound 3, half-maximal effective concentration: 20000 nM
Estimate against measurement, compound 3: 8.0-fold (0.90 log units) below; measured number above the stated range.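

In this assay, the place that holds the ethyl group of compound 1 proves sensitive to substitution: 2-methyl-4-(trifluoromethyl)phenyl in place of ethyl gives a 20-fold higher number from compound 1 to compound 3 (1.30 log units; beyond the scatter). The earlier step at the butyl group could not be sized, as compound 2 gives a limit of the assay and not a number: the limit of > 29000 nM in this assay, at which 1 of the 3 values shown sits. Going by these compounds alone, this new step ends on an actual number, so it is the first whose full size can be read, and it shows that a change at this second place on the core also moves the read-out.

From the compounds shown here alone, whether the step follows the added aromatic ring itself or its methyl and trifluoromethyl groups remains open. Unsubstituted phenyl, or a propyl chain, in place of ethyl would separate these readings.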